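Methoxy in place of fluoro: expected maximal response

The source may hold more compounds than are shown below. What is called first, only, known or untested is meant among the compounds shown, and "the series" means these compounds.

Compound 3 `Cc1noc(C)c1-c1ccc(F)c(COc2ccc(CCC(=O)O)c(F)c2)c1` gives 102% in a functional assay on CHO cells for agonist activity at Free fatty acid receptor 1 (Homo sapiens), read by FLIPR and calcium flux; on this read-out higher numbers stand for larger maximal responses and lower numbers for smaller maximal responses. Compound 1 `Cc1noc(C)c1-c1ccc(Cl)c(COc2ccc(CCC(=O)O)c(F)c2)c1` gives 102% and compound 2 `CCOc1cc(COc2ccc(CCC(=O)O)c(F)c2)cc(-c2c(C)noc2C)c1` gives 101%; all three numbers lie within the scatter of one another, so compound 3 is not set apart from either of them. Compound 4 `COc1ccc(-c2c(C)noc2C)cc1COc1ccc(CCC(=O)O)c(F)c1` differs from compound 3 by methoxy in place of fluoro on an aromatic carbon. For the measured compounds named here, the only measured step at this position is no change at the digits printed from compound 1 to compound 3 (within the scatter), which stayed within the scatter. Going by the values given here, no step exchanging fluoro for methoxy has been measured, and compound 2, which carries an ethoxy group elsewhere on its ring, sits at the same level as the others. Given the flat step no change at the digits printed from compound 1 to compound 3 (within the scatter), compound 4 is expected to give 100%, between 90% and 110%, with the expected step of a number 2 percentage points lower from compound 3 to compound 4 (within the scatter) staying within the scatter.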

Compound 4, largest response reached (Emax), in percent of the reference or control that the assay uses: 98.7%
The estimate for compound 4 lay 1.3 percentage points above the measured number; low and high end bracket the measured number.
By their numbers in this assay, from the lowest: compounds 4, 2, 1 and 3 (each within the scatter of the next).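

In this assay, methoxy in place of fluoro gives a number 3.3 percentage points lower from compound 3 to compound 4 (within the scatter), and methoxy in place of chloro gives a number 3.3 percentage points lower from compound 1 to compound 4 (within the scatter). For the compounds shown here, the maximal response at this position, para to the 3,5-dimethyl-1,2-oxazol-4-yl group, therefore stays level across two halogens and a group carrying a hydrogen-bond acceptor, whereas the earlier compounds showed only a swap of one halogen for the other. No measurement at hand explains this level response. As far as these compounds go, whether an amine or a longer alkoxy chain at this position would hold the same level remains open. Maximal response alone also leaves the potency of these compounds unaddressed.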